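From diethylamino to (tert-butyl)amino on a shared core

This account rests on a few compounds, and the source may have more. Where it says the series, first, only, none or still open, it means among the compounds named here.

Compound 1 `O=C(C1C(=O)N(O)C(=O)c2ccccc21)N1CCCCC1`: 120000 nM
Compound 2 `CC(C)NC(=O)C1C(=O)N(O)C(=O)c2ccccc21`: 163000 nM
Compound 3 `CCN(CC)C(=O)C1C(=O)N(O)C(=O)c2ccccc21`: 28000 nM

These values come from an ADME assay on MT4 cells (Homo sapiens) for cytotoxicity, read by MTT assay; a lower number here means that less compound is tolerated, a higher number that more compound is tolerated. Compound 3 gives the lowest of the three numbers, 28000 nM. Compound 4 `CC(C)(C)NC(=O)C1C(=O)N(O)C(=O)c2ccccc21` has not been measured yet. It carries (tert-butyl)amino in place of diethylamino on a carbonyl carbon. Like (tert-butyl)amino, isopropylamino keeps the amide hydrogen, and it gives way to diethylamino in a 5.8-fold lower number from compound 2 to compound 3 (0.77 log units; beyond the scatter). Against any firm rule about that hydrogen stands a 4.3-fold lower number from compound 1 to compound 3 (0.63 log units; beyond the scatter), a step of similar size without it. A rise of about that size is therefore expected, a 3.9-fold higher number from compound 3 to compound 4 (0.59 log units; beyond the scatter). Compound 4 is estimated at 110000 nM, with an expected range of 40000 nM to 250000 nM.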

Compound 4, half-maximal cytotoxic concentration: 142000 nM
The estimate for compound 4 lay 1.3-fold (0.11 log units) below the measured number; the measured number falls inside the stated range.
By their numbers in this assay, from the lowest: compound 3; then compounds 1, 4 and 2 (each within the scatter of the next).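

Diethylamino and (tert-butyl)amino hold the same atoms joined differently, yet the swap gives a 5.1-fold higher number from compound 3 to compound 4 (0.71 log units; beyond the scatter), so at this carbonyl carbon the arrangement of those atoms matters and not only their number. An extra methyl on isopropylamino gives a 1.1-fold lower number from compound 2 to compound 4 (0.06 log units; within the scatter), which is within the scatter. The change from piperidin-1-yl gives a 1.2-fold higher number from compound 1 to compound 4 (0.07 log units; within the scatter), also within the scatter, so compound 1, without the amide hydrogen, sits with compounds that keep it, and that hydrogen alone does not sort these results.

Nothing shown explains why compound 3 stands apart. As far as these compounds go, how morpholin-4-yl or a longer chain such as n-butylamino would behave on this carbonyl carbon remains open.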